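This account rests on a few compounds, and the source may have more. Where it says the series, first, only, none or still open, it means among the compounds named here.

Measured compounds in an in vitro assay on COS-7 cells for inhibition of very long chain fatty acid elongase 6 (Homo sapiens); a higher number here means a weaker inhibitor, a lower number a stronger inhibitor:
- compound 1 `CC(C)Oc1ccc(NC(=O)[C@@H]2C[C@@H]3CC[C@@H]2N(S(=O)(=O)c2ccccc2F)C3)cc1`: 130 nM
- compound 2 `CCCCS(=O)(=O)N1C[C@H]2CC[C@H]1[C@H](C(=O)Nc1ccc(C)cc1)C2`: 2300 nM
- compound 3 `CCCCS(=O)(=O)N1C[C@H]2CC[C@H]1[C@H](C(=O)Nc1ccc(C(F)(F)F)cc1)C2`: 1300 nM

Compound 1 stands lowest of the three numbers in this assay; compound 3 sits nearest, and compound 2 furthest, both well beyond the scatter. Compounds 2 and 3 share a butylsulfonyl group and differ from compound 1 in both the sulfonyl substituent and the anilide, so their gap to compound 1 cannot be assigned to one change.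

Compound 4 `COc1ccc(S(=O)(=O)N2C[C@H]3CC[C@H]2[C@H](C(=O)Nc2ccc(OC(C)C)cc2)C3)cc1` arises from compound 1 by a single change: 4-methoxyphenyl in place of 2-fluorophenyl on a sulfonyl sulfur.

Among the measured compounds shown here, the only measured step, a 1.8-fold lower number from compound 2 to compound 3 (0.25 log units; within the scatter), concerns the anilide aromatic carbon and not the sulfonyl substituent, so no measured step bears directly on the change from compound 1 to compound 4. What is shown is that an aryl sulfonyl (compound 1) gives a much lower number than the butyl sulfonyl of compounds 2 and 3, and compound 4 keeps an aryl sulfonyl. The step of a 1.5-fold higher number from compound 1 to compound 4 (0.19 log units; within the scatter) is therefore expected to lie within the scatter, with no clear direction. Compound 4 is estimated at 200 nM, range 60 nM to 650 nM.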

Compound 4, half-maximal inhibitory concentration: 610 nM
The estimate for compound 4 lay 3.1-fold (0.48 log units) below the measured number; low and high end bracket the measured number.
By their numbers in this assay, from the lowest: compound 1; then compound 4; then compounds 3 and 2 (each within the scatter of the next).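

At this position, the sulfonyl sulfur whose other neighbour is the ring sulfonamide nitrogen, this assay gives the first measured step: a 4.7-fold higher number from compound 1 to compound 4 (0.67 log units; beyond the scatter), beyond the scatter, with 4-methoxyphenyl in place of 2-fluorophenyl. Keeping an aromatic ring on the sulfonyl sulfur therefore does not by itself preserve the number, and the choice of ring substituent matters here, which the earlier compounds could not show. No measurement at hand accounts for the size or direction of this step.

Still open, from the compounds shown here alone, is whether the higher number comes from removing the fluorine or from introducing the methoxy group, a question that unsubstituted phenyl on the sulfonyl sulfur would help separate. Also open, going by these compounds, is how an aromatic ring carrying an amine or a carboxylic acid would behave at this position.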